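The compounds below may be only part of what the source reports. "The series", "measured", "known", "first", "only" and "open" are said of these compounds alone.

Compound 1 `c1ccc(-c2cn3ccnc3c(-c3ccc4ncn(C5CCCCC5)c4c3)n2)cc1`: in a functional assay on HCT-116 cells (Homo sapiens) for inhibition, read by sulforhodamine B assay, with a stated time of 48 h, tested at 10 uM (a higher number here means more inhibition at the concentration tested (going by the name of the read-out), a lower number less inhibition), compound 1 gives 59.5%
Compound 2 `O=Cc1ccc(-c2cn3ccnc3c(-c3ccc4ncn(C5CCCCC5)c4c3)n2)cc1`: in this assay compound 2 gives 92.6%

Within the data shown here, compound 2 stands highest of the two measured compounds in this assay, its only neighbour being compound 1. Among the measured compounds shown here, the sole measured step, a number 33.1 percentage points higher from compound 1 to compound 2 (beyond the scatter), is the one that bears on compound 3 `Fc1ccc(-c2cn3ccnc3c(-c3ccc4ncn(C5CCCCC5)c4c3)n2)cc1`, which differs from compound 2 by fluoro in place of formyl on an aromatic carbon. That step was large, and it was the formyl group that came in there. Since the formyl now leaves again and only a fluoro enters, compound 3 is expected to move by a number 27.6 percentage points lower from compound 2 to compound 3 (beyond the scatter) in this assay, landing near 65%, within a range from 45% to 85%.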

Compound 3, a percentage reported as inhibition, at one concentration (the size of the read-out at that concentration, not a potency): 18%
Beside the measured number, compound 3's estimate is 47 percentage points above it; measured number below the stated range.
By their numbers in this assay, from the lowest: compound 3; then compound 1; then compound 2.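

In this assay, the earlier pair showed only a rise at this position, with formyl above hydrogen; compound 3 shows that a substituent here can also lower the reading well below that of hydrogen, with fluoro in place of hydrogen giving a number 41.5 percentage points lower from compound 1 to compound 3 (beyond the scatter). Fluoro in place of formyl gives a number 74.6 percentage points lower from compound 2 to compound 3 (beyond the scatter), so the identity of the group at this position strongly shapes the result. Nothing measured here accounts for this drop. Going by these compounds, whether other groups at this place, such as an amine, a carboxylic acid or a nitrile, would fall nearer compound 2 or compound 3 remains open.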